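A few compounds are considered here, and "the series" means these few. Any claim that something is new, unique, unknown or untested is made for them only; others in the source may bear on it.

Compound 1 `C=CC(=O)Nc1cccc(Nc2nc(N/N=C(\C)c3ccc(C)cc3)ncc2Cl)c1` and compound 2 `C=CC(=O)Nc1cccc(Nc2nc(N/N=C(\C)c3ccc(OC)cc3)ncc2Cl)c1` share one core and differ in a single place: methoxy in place of methyl on an aromatic carbon In an ADME assay on HT-29 cells (Homo sapiens) for inhibition, read by MTT assay, with a stated time of 72 h (a higher number here means a weaker inhibitor, a lower number a stronger inhibitor), compound 1 gives 3210 nM and compound 2 gives 4560 nM; the step of a 1.4-fold higher number from compound 1 to compound 2 (0.15 log units; within the scatter) lies within the usual scatter of repeated measurements, so the two compounds cannot be ordered against each other.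

Compound 3 `C/C(=N\Nc1ncc(Cl)c(Nc2cccc(NC(=O)/C=C/CN(C)C)c2)n1)c1ccc(C)cc1` carries a different core, and how it departs from compound 1 is counted here: 3-(dimethylamino)prop-1-en-1-yl in place of vinyl on a carbonyl carbon In this assay compound 3 gives 11800 nM, and the step of a 3.7-fold higher number from compound 1 to compound 3 (0.57 log units; beyond the scatter) stands beyond the scatter, so compound 3 is the weaker inhibitor of the pair. Among the three measured compounds, compound 3 has the highest number, beyond the scatter from both compound 2 and compound 1.

Compound 4 `COc1ccc(/C(C)=N/Nc2ncc(Cl)c(Nc3cccc(NC(=O)/C=C/CN(C)C)c3)n2)cc1` stands to compound 3 as compound 2 stands to compound 1: methoxy in place of methyl on an aromatic carbon The place is the same word for word, so this is the same change, now made on the core of compound 3. Since this change produced only a small step from compound 1 to compound 2, a step of similar size is expected from compound 3 to compound 4 in this assay, namely a 1.4-fold higher number from compound 3 to compound 4 (0.13 log units; within the scatter). On that basis compound 4 is estimated to give 16000 nM in this assay, with an expected range from 8000 nM to 35000 nM.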

Compound 4, half-maximal inhibitory concentration: 6830 nM
Estimate against measurement, compound 4: 2.3-fold (0.37 log units) above; measured number outside the range, below it.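

Made on the core of compound 3, the exchange of methyl for methoxy gives a 1.7-fold lower number from compound 3 to compound 4 (0.24 log units; within the scatter) in this assay, and set beside its earlier outing the step shows no difference between the two cores that exceeds the scatter: the same change on two cores in this assay, a 1.4-fold higher number (0.15 log units; within the scatter) from compound 1 to compound 2 and a 1.7-fold lower number (0.24 log units; within the scatter) from compound 3 to compound 4, 2.5-fold (0.39 log units) apart, within the scatter of two such steps.

The exchange of vinyl for 3-(dimethylamino)prop-1-en-1-yl, read on the methoxy-bearing core, gives a 1.5-fold higher number from compound 2 to compound 4 (0.18 log units; within the scatter), and although only its earlier counterpart stands beyond the scatter, the two steps cannot be told apart either: the same change on two cores in this assay, a 3.7-fold higher number (0.57 log units; beyond the scatter) from compound 1 to compound 3 and a 1.5-fold higher number (0.18 log units; within the scatter) from compound 2 to compound 4, 2.5-fold (0.39 log units) apart, within the scatter of two such steps.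

Both changes are therefore compatible with carrying over from one core to the other, but this rests on a single pair of steps for each change, and it neither proves that the steps are equal nor assigns the methoxy change a direction on either core.

The compounds shown leave open whether a chlorine, an ethoxy or a hydroxy group on that aromatic carbon would follow the same course as methoxy. They also leave open whether a morpholine or a piperidine in place of the dimethylamino group would give steps like those seen here, on either core.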